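The compounds below may be only part of what the source reports. "The series", "measured", "known", "first", "only" and "open" are said of these compounds alone.

Working notes on the series, step from compound 1 to compound 4. Compound 1 `COc1ccc(/C=C/c2cc(OC)cc(OC)c2/C=C/C(=O)c2ccccc2)cc1` gives 3.9 ug/mL in a functional assay on A549 cells (Homo sapiens) for antiproliferative activity, read by MTT assay, with a stated time of 48 h (a lower number here means a stronger inhibitor, a higher number a weaker inhibitor), the lowest of the three numbers in hand. Compound 2 `COc1ccc(/C=C/c2cc(OC)cc(OC)c2/C=C/C(=O)c2ccc(C(F)(F)F)cc2)cc1` gives 7.8 ug/mL and compound 3 `COc1ccc(/C=C/c2cc(OC)cc(OC)c2/C=C/C(=O)c2ccc(Br)cc2)cc1` gives 8.3 ug/mL. The change from compound 1 to compound 4 `COc1ccc(/C=C/c2cc(OC)cc(OC)c2/C=C/C(=O)c2ccc(OC)cc2)cc1` is methoxy in place of hydrogen on an aromatic carbon. Among the measured compounds shown here, two measured steps bear on it, each placing a group on an aromatic carbon of compound 1: a 2.0-fold higher number from compound 1 to compound 2 (0.30 log units; within the scatter) and a 2.1-fold higher number from compound 1 to compound 3 (0.33 log units; beyond the scatter); between those two products a 1.1-fold higher number from compound 2 to compound 3 (0.03 log units; within the scatter). For the measured compounds named here, no step adding methoxy at that place has been measured. A small rise in the number, or none beyond the scatter, is therefore expected in this assay. Compound 4 is estimated at 6 ug/mL with a range of 3 ug/mL to 12 ug/mL. The expected step is a 1.5-fold higher number from compound 1 to compound 4 (0.19 log units; within the scatter).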

Compound 4, half-maximal inhibitory concentration: 4.5 ug/mL
Beside the measured number, compound 4's estimate is 1.3-fold (0.12 log units) above it, within the range that was stated.
By their numbers in this assay, from the lowest: compounds 1, 4, 2 and 3 (each within the scatter of the next, the first and the last beyond it).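

In this assay, the step of a 1.2-fold higher number from compound 1 to compound 4 (0.06 log units; within the scatter) shows that methoxy, on this aromatic carbon para to a large group, stays within the scatter of hydrogen, whereas bromo in compound 3 does not. Methoxy also cannot be separated from the other two groups at this place, with a 1.8-fold lower number from compound 3 to compound 4 (0.27 log units; within the scatter) and a 1.7-fold lower number from compound 2 to compound 4 (0.24 log units; within the scatter) both read as within the scatter. Nothing in hand gives a reason for these results. As far as these compounds go, whether an amine or a carboxylic acid at this place would stay within the scatter of compound 1 remains open. Also open, from the compounds shown here alone, is whether methoxy would behave the same way elsewhere on this ring.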